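Compound 2 to compound 3: one further fluoro

The compounds below may be only part of what the source reports. "The series", "measured", "known", "first", "only" and "open" are said of these compounds alone.

In a functional assay on HT-29 cells (Homo sapiens) for antiproliferative activity, read by MTT assay, with a stated time of 72 h (a higher number here means a weaker inhibitor, a lower number a stronger inhibitor), compound 2 `Nc1nc(N)c2cc(CSC(=S)N3CCN(c4ccccc4F)CC3)ccc2n1` gives 5420 nM, within the scatter of compound 1 `Cc1ccc(N2CCN(C(=S)SCc3ccc4nc(N)nc(N)c4c3)CC2)c(C)c1` at 2970 nM. Within the data shown here, these are the only two measured compounds, so neither can be ranked above the other.

Compound 3 `Nc1nc(N)c2cc(CSC(=S)N3CCN(c4ccc(F)cc4F)CC3)ccc2n1` carries 2,4-difluorophenyl where compound 2 carries 2-fluorophenyl: fluoro in place of hydrogen on an aromatic carbon, para to a large group and meta to a fluoro group (fluoro in place of hydrogen on an aromatic carbon).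

Among the measured compounds shown here, the only measured step bearing on this is a 1.8-fold higher number from compound 1 to compound 2 (0.26 log units; within the scatter), which puts 2-fluorophenyl in place of 2,4-dimethylphenyl on an amine nitrogen in a ring. For the measured compounds named here, no measured step isolates the added fluoro itself. No step beyond the scatter is therefore expected in this assay. The expected size is a 1.2-fold lower number from compound 2 to compound 3 (0.08 log units; within the scatter). Compound 3 is estimated at 4500 nM, with an expected range of 1800 nM to 11000 nM.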

Compound 3, half-maximal inhibitory concentration: 5020 nM
Compound 3: the middle estimate sits 1.1-fold (0.05 log units) below what was measured; low and high end bracket the measured number.
By their numbers in this assay, from the lowest: compounds 1, 3 and 2 (each within the scatter of the next).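

In this assay, fluoro in place of hydrogen on the aromatic carbon para to a large group gives a 1.1-fold lower number from compound 2 to compound 3 (0.03 log units; within the scatter), so this position takes the added fluoro without a step beyond the scatter. The swap of the whole aryl group reads as a 1.7-fold higher number from compound 1 to compound 3 (0.23 log units; within the scatter), which also lies within the scatter, so 2,4-difluorophenyl and 2,4-dimethylphenyl on the amine nitrogen cannot be told apart here. No supporting evidence bears on why these numbers stay so close.

As far as these compounds go, whether a larger or charged group at this carbon, such as a methoxy group, an amine or a carboxylic acid, would produce a step beyond the scatter in this assay remains open. Only the aryl group varies among the compounds shown, so the contribution of the shared core and its linking chain also remains open.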